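The source may hold more compounds than are shown below. What is called first, only, known or untested is meant among the compounds shown, and "the series" means these compounds.

Compound 1, `Cc1nn(-c2ncnc3nc[nH]c23)c2c1C(OCc1ccc(C(C)C)cc1)CC(=O)N2`: in a functional assay on HEK293 cells for agonist activity at G-protein coupled receptor 39 (Homo sapiens), read by scintillation proximity assay and inositol phosphate accumulation, with a stated time of 75 min (on this read-out higher numbers stand for an effect only at larger amounts of compound and lower numbers for an effect already at smaller amounts), compound 1 gives 1690 nM.
Compound 2, `Cc1nn(-c2ncnc3nc[nH]c23)c2c1C(OCCc1ccccc1)CC(=O)N2`: in this assay compound 2 gives 40 nM.

For the measured compounds named here, compound 2 holds the lowest of the two numbers; the only measured step, a 42-fold lower number from compound 1 to compound 2 (1.63 log units; beyond the scatter), is a large one and sets the whole span. Compound 3, `COc1ccc(CCOC2CC(=O)Nc3c2c(C)nn3-c2ncnc3nc[nH]c23)cc1`, differs from compound 2 by methoxy in place of hydrogen on an aromatic carbon. That measured step swaps the whole aromatic group, so it bears only loosely on a single added methoxy. A modest step is therefore expected, a 1.5-fold higher number from compound 2 to compound 3 (0.18 log units; within the scatter), and compound 3 is estimated at 60 nM, with a range from 20 nM to 200 nM.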

Compound 3, half-maximal effective concentration: 70 nM
Compound 3: the middle estimate sits 1.2-fold (0.07 log units) below what was measured; measured number inside the range.
By their numbers in this assay, from the lowest: compounds 2 and 3 (each within the scatter of the next); then compound 1.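

In this assay, methoxy in place of hydrogen on an aromatic carbon, para to a large group, gives a 1.8-fold higher number from compound 2 to compound 3 (0.24 log units; within the scatter), so this position accepts methoxy within the scatter. The result stays far from compound 1, with a 24-fold lower number from compound 1 to compound 3 (1.38 log units; beyond the scatter), so a substituent on this aromatic ring does not by itself bring back the high number of compound 1. Nothing available explains either step. On these data alone, whether isopropyl at this same carbon would be accepted on the phenethyl group remains open, which leaves the source of the large step unsettled. As far as these compounds go, how an amine or a carboxylic acid would fare here is also open.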